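Replacing a nitrile with a propylamide on the outer ring

A few compounds are considered here, and "the series" means these few. Any claim that something is new, unique, unknown or untested is made for them only; others in the source may bear on it.

Within the data shown here, compound 2 `COc1cc2c(cc1OC)CN(Cc1ccc(OC)c3oc(-c4cccc(C#N)c4)cc13)CC2` holds the lowest of the two numbers so far in an assay on HepG2 cells for displacement of a labelled ligand from Alpha-2C adrenergic receptor (Homo sapiens), tested at 0.1 uM (on this read-out lower numbers stand for less inhibition and higher numbers for more inhibition at the one concentration tested (going by the name of the read-out)), where compound 2 gives 42%. Its nearest neighbour, compound 1 `COc1cc2c(cc1OC)CN(Cc1ccc(OC)c3oc(-c4cccnc4)cc13)CC2`, gives 62% in this assay. Among the measured compounds shown here, the single measured step, a number 20 percentage points lower from compound 1 to compound 2 (beyond the scatter), exchanged one ring for another and is the only comparison available.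

Compound 3 `CCCNC(=O)c1cccc(-c2cc3c(CN4CCc5cc(OC)c(OC)cc5C4)ccc(OC)c3o2)c1` is the next compound to be tested. It differs from compound 2 in one place: propylcarbamoyl in place of cyano on an aromatic carbon. For the measured compounds named here, no measured step touches this kind of exchange, since the one step seen swapped an aromatic ring rather than a group hanging from it. It therefore gives no guide to direction, and the expectation rests on compound 2 alone.

With nothing to push the number either way, compound 3 is expected to land near the value of compound 2, with the step of a number 2 percentage points lower from compound 2 to compound 3 (within the scatter) expected to stay within the scatter. The estimate for compound 3 in this assay is 40%, with a range from 15% to 65% to reflect the lack of any precedent.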

Compound 3, a percentage reported as inhibition, at one concentration (the size of the read-out at that concentration, not a potency): 48%
The estimate for compound 3 lay 8 percentage points below the measured number, and the stated range covers the measured number.
By their numbers in this assay, from the lowest: compounds 2 and 3 (each within the scatter of the next); then compound 1.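

Swapping cyano for propylcarbamoyl on this six-membered aromatic ring of carbon only is the first change shown at a group hanging from the outer ring, rather than at the ring itself. In this assay, a number 6 percentage points higher from compound 2 to compound 3 (within the scatter), so going from the 2 heavy atoms of cyano to the 6 of propylcarbamoyl, which adds an amide hydrogen, leaves the read-out unresolved from that of the nitrile. The other comparison, a number 14 percentage points lower from compound 1 to compound 3 (beyond the scatter), shows that a second 3-substituted phenyl compound also sits apart from the pyridin-3-yl compound, so compound 1 stays above both compound 2 and compound 3, though a single inhibition figure at one concentration is not a potency. Nothing available explains why these numbers fall as they do.

Open, as far as these compounds go, is whether this position stays as undiscriminating for very different groups, such as a carboxylic acid, an aminomethyl group or an amide with a longer chain than propyl. Also open, from the compounds shown here alone, is whether propylcarbamoyl would give a similar number on a pyridine ring like that of compound 1, which would show whether the ring or its substituent matters more.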